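A few compounds are considered here, and "the series" means these few. Any claim that something is new, unique, unknown or untested is made for them only; others in the source may bear on it.

Compound 1 `COc1ccc2c(=O)c(/C=C/C(=O)Nc3cc(C)ccc3C)coc2c1` gives 15500 nM in a functional assay on A549 cells (Homo sapiens) for inhibition, read by MTT assay, with a stated time of 48 h; on this read-out lower numbers stand for stronger inhibition and higher numbers for weaker inhibition.
Compound 2 `COc1ccc2c(=O)c(/C=C/C(=O)Nc3ccc(Cl)cc3)coc2c1` reaches only a limit of this assay, > 100000 nM, which is not a number.
Compound 3 `COc1ccc2c(=O)c(/C=C/C(=O)Nc3ccc(F)cc3)coc2c1` gives 26800 nM in this assay.

Of the two numbers given, compound 3 has the larger, though the step of a 1.7-fold higher number from compound 1 to compound 3 (0.24 log units; within the scatter) lies within the scatter. Compound 4 `CCOc1ccc(NC(=O)/C=C/c2coc3cc(OC)ccc3c2=O)cc1` carries ethoxy in place of fluoro on an aromatic carbon. Among the compounds with values here, two measured steps touch this position: an at least 3.7-fold lower number from compound 2 to compound 3 (0.57 log units; beyond the scatter) moved the number beyond the scatter, while a 1.7-fold higher number from compound 1 to compound 3 (0.24 log units; within the scatter) did not. Within the data shown here, no measured compound carries an ethoxy group, so the direction of the change is open, and only a modest step is anticipated. Compound 4 is therefore expected at 30000 nM, within a range from 10000 nM to 100000 nM, corresponding to an estimated step of a 1.1-fold higher number from compound 3 to compound 4 (0.05 log units; within the scatter).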

Compound 4, half-maximal inhibitory concentration: > 100000 nM
Compound 4 gave a limit, no number; the forecaster's own chance of this, stated with the estimate: 25%; middle value at least 3.3-fold (0.52 log units) away from the limit.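

Placed para to a large group, ethoxy behaves like chloro rather than fluoro: replacing fluoro with ethoxy gives an at least 3.7-fold higher number from compound 3 to compound 4 (0.57 log units; beyond the scatter), and the 4-ethoxyphenyl group in place of 2,5-dimethylphenyl gives an at least 6.4-fold higher number from compound 1 to compound 4 (0.80 log units; beyond the scatter). As far as these compounds go, both steps rest on a limit, not a number, for compound 4, so their true size stays unknown. Of the three groups at this position, only fluoro yields a number, and compound 2 and compound 4 cannot be ranked, as the step between them cannot be read: the limit of > 100000 nM in this assay, at which 2 of the 4 values shown sit.

From the compounds shown here alone, whether an amine or a hydroxyl group at this position would return a number remains open. So does the effect of a methyl group here.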